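Shifting the dimethylphenyl group of compound 3

The source may report more compounds than this note shows. Statements on the series, on what has been measured and on what is new or still open speak of the compounds shown alone.

Measured in an ADME assay (liver) for metabolic stability, with Liver microsome (Homo sapiens) as the target, read by LC-MS, using microsomes, with a stated time of 1 h, tested at 5 uM; a lower number here means that less of the compound is left, a higher number that more of the compound is left:
Compound 1 `Cc1nc(-c2ccccc2)c(C(=O)N2CCN(c3cccc(Cl)c3)CC2)o1`: 13.5%
Compound 2 `Cc1nc(-c2ccccc2)c(C(=O)N2CCN(c3cccc(C)c3C)CC2)o1`: 29.8%
Compound 3 `Cc1ccc(C)c(N2CCN(C(=O)c3oc(C)nc3-c3ccccc3)CC2)c1`: 33.8%

Compound 3 shares the top of this small set with compound 2, and the two cannot be told apart, since the gap between them is a number 4 percentage points higher from compound 2 to compound 3 (within the scatter). Both stand clear of compound 1, which carries a 3-chlorophenyl group. The measured steps are a number 20.3 percentage points higher from compound 1 to compound 3 (beyond the scatter) and a number 16.3 percentage points higher from compound 1 to compound 2 (beyond the scatter).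

Compound 4 `Cc1cc(C)cc(N2CCN(C(=O)c3oc(C)nc3-c3ccccc3)CC2)c1` has the same atoms as compound 3, joined differently: 3,5-dimethylphenyl in place of 2,5-dimethylphenyl on an amine nitrogen in a ring. Its 3,5-dimethylphenyl group sits on the same amine nitrogen in a ring. For the measured compounds named here, the closest precedent is the one swap between two dimethylphenyl groups, from compound 2 to compound 3, which stayed within the scatter. No step beyond the scatter is therefore expected in this assay. The modest steps from compound 1 show that this group can shift the number, so a small drop is allowed for. The estimated step is a number 5.8 percentage points lower from compound 3 to compound 4 (within the scatter). Compound 4 is expected at 28%, with an estimated range of 14% to 42%.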

Compound 4, percent of the compound remaining: 25.6%
For compound 4 the middle estimate is 2.4 percentage points above the measured one, and the stated range covers the measured number.
By their numbers in this assay, from the lowest: compound 1; then compounds 4, 2 and 3 (each within the scatter of the next).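

In this assay, a third arrangement of the two methyl groups reads like the other two, with a number 8.2 percentage points lower from compound 3 to compound 4 (within the scatter) and a number 4.2 percentage points lower from compound 2 to compound 4 (within the scatter), so among the three dimethylphenyl groups shown, moving the methyl groups gives no step beyond the scatter. The 3,5-dimethylphenyl group also stands clear of the 3-chlorophenyl group, with a number 12.1 percentage points higher from compound 1 to compound 4 (beyond the scatter), which makes all three dimethylphenyl compounds in this set read above compound 1, with none going against this. Nothing available explains why these numbers fall as they do.

Still open, going by these compounds, is how a methoxy group or a nitrile on this phenyl ring, or a pyridine ring in its place, would read. These four compounds also share one core, so they say nothing about changes made elsewhere in it.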